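From 4-fluorophenyl to 4-fluorobenzyl on an amide-type nitrogen

The source may report more compounds than this note shows. Statements on the series, on what has been measured and on what is new or still open speak of the compounds shown alone.

Measured in a functional assay on MDA-MB-468 cells (Homo sapiens) for inhibition, read by MTT assay; a higher number here means a weaker inhibitor of growth, a lower number a stronger inhibitor of growth:
Compound 1 `CC1=C(/C=C/C(C)=C/C=C/C(C)=C\C(=O)Nc2ccc(O)cc2)C(C)(C)CCC1n1ccnc1`: 6830 nM
Compound 2 `CC1=C(/C=C/C(C)=C/C=C/C(C)=C\C(=O)Nc2ccc(F)cc2)C(C)(C)CCC1n1ccnc1`: 4570 nM

Compound 2, at 4570 nM, cannot be told apart from compound 1, at 6830 nM. Among the measured compounds shown here, the single measured step, a 1.5-fold lower number from compound 1 to compound 2 (0.17 log units; within the scatter), lies within the scatter, so the two compounds cannot be ranked. That step puts fluoro in place of hydroxy on an aromatic carbon.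

Compound 3 `CC1=C(/C=C/C(C)=C/C=C/C(C)=C\C(=O)NCc2ccc(F)cc2)C(C)(C)CCC1n1ccnc1` has not yet been measured. It carries 4-fluorobenzyl in place of 4-fluorophenyl on an amide-type nitrogen. For the measured compounds named here, no measured step covers a change at this place, so the step from fluoro to hydroxy bears on it only loosely. The data give no direction for the new change, and a wide range is warranted. With nothing pointing to a shift, no step beyond the scatter is expected, and the estimated step is a 1.1-fold higher number from compound 2 to compound 3 (0.04 log units; within the scatter). For compound 3 the expected value is 5000 nM, within an estimated range of 2000 nM to 12000 nM.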

Compound 3, concentration for 50% growth inhibition: 2450 nM
Compound 3: the middle estimate sits 2.0-fold (0.31 log units) above what was measured; the measured number falls inside the stated range.
By their numbers in this assay, from the lowest: compounds 3, 2 and 1 (each within the scatter of the next, the first and the last beyond it).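

In this assay, among the compounds shown here, compounds 1 and 2 differ only in the group on the aromatic ring, whereas compound 3 is the first to change how that ring is attached to the amide-type nitrogen, with 4-fluorobenzyl in place of 4-fluorophenyl. This change gives a 1.9-fold lower number from compound 2 to compound 3 (0.27 log units; within the scatter), so the amide-type nitrogen accepts the benzyl group with no shift that can be told from the scatter, although two compounds cannot show how general this is. The comparison with the hydroxy compound gives a 2.8-fold lower number from compound 1 to compound 3 (0.45 log units; beyond the scatter), the only step here beyond the scatter and a modest one; since it replaces 4-hydroxyphenyl with 4-fluorobenzyl, and nothing shown here explains the difference, it cannot be divided between the fluoro group and the benzyl attachment.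

The compounds shown leave open whether 4-hydroxybenzyl on the same nitrogen would match compound 3 or fall nearer compound 1, which would help separate those two parts of the change. They also leave open whether a longer chain, such as 2-(4-fluorophenyl)ethyl, or an amine or carboxylic acid on the aromatic ring, would move the number beyond the scatter.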